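Hydroxymethyl in place of methoxycarbonyl in a TRPV1 antagonist series

This account rests on a few compounds, and the source may have more. Where it says the series, first, only, none or still open, it means among the compounds named here.

Compound 1 `FC(F)(F)c1ccc(Nc2ncnc3sc(Nc4c(Cl)cccc4Cl)nc23)cc1`: 3 nM
Compound 2 `COC(=O)c1cc(Cl)c(Nc2nc3c(Nc4ccc(C(F)(F)F)cc4)ncnc3s2)c(Cl)c1`: 3190 nM

Within the data shown here, in a functional assay on HEK293 cells for antagonist activity at transient receptor potential cation channel subfamily V member 1 (Rattus norvegicus), read by calcium flux (a higher number here means a weaker inhibitor, a lower number a stronger inhibitor), compound 1 gives 3 nM, and compound 2 gives 3190 nM, the highest of the two numbers measured so far. The two differ only by the methoxycarbonyl group, and that one change produced a 1100-fold higher number from compound 1 to compound 2 (3.03 log units; beyond the scatter). Compound 3 `OCc1cc(Cl)c(Nc2nc3c(Nc4ccc(C(F)(F)F)cc4)ncnc3s2)c(Cl)c1` has not yet been measured. It keeps everything of compound 2 except for (hydroxymethyl in place of methoxycarbonyl on an aromatic carbon). Among the measured compounds shown here, the only measured step that bears on this position is a 1100-fold higher number from compound 1 to compound 2 (3.03 log units; beyond the scatter), which shows that methoxycarbonyl at this aromatic carbon is costly against the unsubstituted compound 1. For the measured compounds named here, nothing is known about hydroxymethyl at the same carbon, so the expectation rests on the single fact that the group giving the large loss is removed and a different, smaller substituent, as counted above, is put in its place. A partial recovery is expected rather than a full return to the level of compound 1, an estimated step of an 8.0-fold lower number from compound 2 to compound 3 (0.90 log units; beyond the scatter) downward, with wide uncertainty. Compound 3 is therefore estimated at 400 nM, with a range from 40 nM to 4000 nM.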

Compound 3, half-maximal inhibitory concentration: 0.5 nM
Compound 3: middle estimate off by 800-fold (2.90 log units), on the high side; measured number outside the range, below it.
By their numbers in this assay, from the lowest: compound 3; then compound 1; then compound 2.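

The aromatic carbon meta to two chloro groups and para to a large group does not reject substitution as such. In this assay, hydroxymethyl in place of methoxycarbonyl gives a 6400-fold lower number from compound 2 to compound 3 (3.80 log units; beyond the scatter) at this carbon, so the earlier loss belongs to methoxycarbonyl and not to every group placed there. Hydroxymethyl also goes beyond restoring the unsubstituted level, with a 6.0-fold lower number from compound 1 to compound 3 (0.78 log units; beyond the scatter) in the same assay, which makes compound 3 the strongest inhibitor of the three, and no measurement shown accounts for the wide gap between these two groups.

The compounds shown leave open which feature of hydroxymethyl goes with this result, since it differs from methoxycarbonyl in heavy atoms, in the double bond and in hydrogen-bond donors all at once. From the compounds shown here alone, a carboxylic acid, a methoxymethyl group, an aminomethyl group or a longer chain such as hydroxyethyl at this carbon would begin to separate those features, and whether the gain survives replacing either chloro group with a methyl group also remains unknown.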